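This account rests on a few compounds, and the source may have more. Where it says the series, first, only, none or still open, it means among the compounds named here.

Compound 3 `Oc1cc(C(F)(F)F)ccc1-c1nc(-c2ccccc2O)n(-c2cccc(Cl)c2)n1` is one of three measured analogues sharing a common core. In a functional assay on PC-12 cells (Rattus norvegicus) for cytotoxicity, read by MTT assay, with stated times of 2 h and 24 h, tested at 5 uM (on this read-out lower numbers stand for a weaker effect and higher numbers for a stronger effect at the one concentration tested), compound 3 gives 92.7%, the second highest of the three numbers; its nearest neighbour is compound 1 `CCc1ccc(-n2nc(-c3ccc(C(F)(F)F)cc3O)nc2-c2ccccc2O)cc1`, which gives 95.4%, and the furthest is compound 2 `Oc1cc(C(F)(F)F)ccc1-c1nc(-c2ccccc2O)n(-c2ccc(Br)cc2)n1`, which gives 89.8%. Both gaps lie within the scatter, so no ordering among the three can be claimed.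

Compound 4 `Oc1cc(C(F)(F)F)ccc1-c1nc(-c2ccccc2O)n(-c2cccc(C(F)(F)F)c2)n1` is not yet measured. It differs from compound 3 by trifluoromethyl in place of chloro on an aromatic carbon: on an aromatic carbon of a six-membered aromatic ring of carbon only.

The steps already seen bear on this change only loosely. The change a number 2.7 percentage points lower from compound 1 to compound 3 (within the scatter) and the change a number 2.9 percentage points higher from compound 2 to compound 3 (within the scatter) both touch the ring on the aromatic nitrogen, and the change a number 5.6 percentage points lower from compound 1 to compound 2 (within the scatter) swaps one substituent on an aromatic carbon for another; each stayed within the scatter. On that basis the step of a number 0.7 percentage points lower from compound 3 to compound 4 (within the scatter) is expected to be none beyond the scatter, in either direction. The estimate for compound 4 in this assay is therefore 92%, with a range from 84% to 98%.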

Compound 4, a percentage reported as activity, at one concentration (the size of the read-out at that concentration, not a potency): 92.2%
Compound 4: the middle estimate sits 0.2 percentage points below what was measured, and the stated range covers the measured number.
By their numbers in this assay, from the lowest: compounds 2, 4, 3 and 1 (each within the scatter of the next).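

On an aromatic carbon of a six-membered aromatic ring of carbon only, meta to a large group, trifluoromethyl with its 4 heavy atoms takes the place of chloro with its 1, and in this assay this gives a number 0.5 percentage points lower from compound 3 to compound 4 (within the scatter), the first step shown at this place on the ring. The two wider comparisons, which alter the group and its place together, give a number 2.4 percentage points higher from compound 2 to compound 4 (within the scatter) and a number 3.2 percentage points lower from compound 1 to compound 4 (within the scatter), so 3-(trifluoromethyl)phenyl can no more be separated from 4-bromophenyl or 4-ethylphenyl on the aromatic nitrogen than 3-chlorophenyl could. All four compounds therefore remain indistinguishable at the one concentration tested, and no measurement shown offers an explanation for this flat picture.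

The compounds shown carry no amine, carboxylic acid or longer alkyl chain on this ring, so it remains open whether any such group would produce a step beyond the scatter. Both hydroxyl groups and the trifluoromethyl on the shared core are also the same throughout, leaving open what happens when any of them is replaced.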